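The compounds below may be only part of what the source reports. "The series", "measured", "known", "first", "only" and "open" are said of these compounds alone.

In an ADME assay on the whole organism (Rattus norvegicus, strain Sprague-Dawley) for pharmacokinetics, read by LC-MS, with a stated time of 48 h, at a dose of 10 mg/kg by the oral route (a lower number here means slower removal, a higher number faster removal of the compound), compound 1 (`CC#CCn1c(N2CCC[C@@H](N)C2)cc(=O)n(Cc2ccc(Br)c(C(=O)OC)c2)c1=O`) gives 14.2 mL/min/kg and compound 2 (`CC#CCn1c(N2CCC[C@@H](N)C2)cc(=O)n(Cc2ccc(F)c(C(=O)OC)c2)c1=O`) gives 3.83 mL/min/kg as the lower of the two numbers. Compound 3 (`CC#CCn1c(N2CCC[C@@H](N)C2)cc(=O)n(Cc2ccc(Cl)c(C(=O)OC)c2)c1=O`) differs from compound 2 by chloro in place of fluoro on an aromatic carbon. Among the compounds with values here, the only measured step bearing on this is a 3.7-fold lower number from compound 1 to compound 2 (0.57 log units; beyond the scatter) for fluoro in place of bromo, so a higher number than for compound 2 is expected in this assay by only part of that size. The expected step is a 2.1-fold higher number from compound 2 to compound 3 (0.32 log units; beyond the scatter) in size. For compound 3 the estimate is 8 mL/min/kg with an expected range from 3.5 mL/min/kg to 18 mL/min/kg as working bounds.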

Compound 3, clearance: 9.17 mL/min/kg
Beside the measured number, compound 3's estimate is 1.1-fold (0.06 log units) below it, within the range that was stated.
By their numbers in this assay, from the lowest: compound 2; then compounds 3 and 1 (each within the scatter of the next).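

In this assay, this position now separates fluoro from the two heavier halogens: a 2.4-fold higher number from compound 2 to compound 3 (0.38 log units; beyond the scatter), whereas a 1.5-fold lower number from compound 1 to compound 3 (0.19 log units; within the scatter). On the aromatic carbon ortho to a methoxycarbonyl group, chloro and bromo therefore cannot be told apart, and fluoro alone stands clear of the scatter. No measurement bears on the cause of this split. Open, from the compounds shown here alone, is whether hydrogen, methyl or a nitrile at this place would group with fluoro or with chloro and bromo. Also open, going by these compounds, is whether the split persists with a carboxylic acid replacing the methoxycarbonyl group.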